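Amide substituent variation on the shared core

This account rests on a few compounds, and the source may have more. Where it says the series, first, only, none or still open, it means among the compounds named here.

Measured so far:
compound 1 `CCn1c(C(=O)NCCN(C)C)ccc1C(CC)(CC)c1ccc(OCCC(O)(CC)CC)c(C)c1` — 82 nM
compound 2 `C#CC(C)OC(=O)c1ccc(C(CC)(CC)c2ccc(OCCC(O)(CC)CC)c(C)c2)n1CC` — 2650 nM
compound 3 `CCn1c(C(=O)Nc2cccc(C(F)(F)F)c2)ccc1C(CC)(CC)c1ccc(OCCC(O)(CC)CC)c(C)c1` — 5900 nM

In an assay on cells for agonist activity at vitamin D3 receptor (Homo sapiens), with a stated time of 96 h (on this read-out lower numbers stand for an effect already at smaller amounts and higher numbers for an effect only at larger amounts of compound), compound 1 gives the lowest number of the three; compound 2 is the nearest to it and compound 3 the furthest. The two measured steps away from compound 1 are both large: a 32-fold higher number from compound 1 to compound 2 (1.51 log units; beyond the scatter) and a 72-fold higher number from compound 1 to compound 3 (1.86 log units; beyond the scatter). Compound 2 and compound 3 differ from each other only modestly, a 2.2-fold higher number from compound 2 to compound 3 (0.35 log units; beyond the scatter).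

Compound 4 `CCn1c(C(=O)N(C)CCO)ccc1C(CC)(CC)c1ccc(OCCC(O)(CC)CC)c(C)c1` has not been measured in this assay. It differs from compound 1 by (2-hydroxyethyl)(methyl)amino in place of (2-(dimethylamino)ethyl)amino on a carbonyl carbon. Both measured steps from compound 1 replace the (2-(dimethylamino)ethyl)amino group on the carbonyl carbon and both raise the number strongly, so the group itself seems to matter; compound 4 keeps an amide-type nitrogen with a short chain but loses the (2-(dimethylamino)ethyl)amino group in favour of (2-hydroxyethyl)(methyl)amino. Neither measured step tests this exact exchange, so the expectation rests on the direction shown by compound 2 and compound 3 rather than on their size. Because a 32-fold higher number from compound 1 to compound 2 (1.51 log units; beyond the scatter) and a 72-fold higher number from compound 1 to compound 3 (1.86 log units; beyond the scatter) are both large, compound 4 is expected to show a loss in the same direction that is smaller than either, estimated as a 4.9-fold higher number from compound 1 to compound 4 (0.69 log units; beyond the scatter). The estimate for compound 4 in this assay is 400 nM, with a range from 120 nM to 1500 nM.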

Compound 4, half-maximal effective concentration: 52.7 nM
Compound 4: middle estimate off by 7.6-fold (0.88 log units), on the high side, outside the stated range (below it).
By their numbers in this assay, from the lowest: compounds 4 and 1 (each within the scatter of the next); then compound 2; then compound 3.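

In this assay the exchange at this carbonyl carbon gives a 1.6-fold lower number from compound 1 to compound 4 (0.19 log units; within the scatter) and so shows that the (2-(dimethylamino)ethyl)amino group is not required for a low number: compound 4 has neither the dimethylamino group nor the amide hydrogen of compound 1, yet the two cannot be told apart. The large steps seen earlier therefore do not follow from removing that group as such, since the (2-hydroxyethyl)(methyl)amino group gives a 110-fold lower number from compound 3 to compound 4 (2.05 log units; beyond the scatter) against the (3-(trifluoromethyl)phenyl)amino group and a 50-fold lower number from compound 2 to compound 4 (1.70 log units; beyond the scatter) against the (1-methylprop-2-yn-1-yl)oxy group on the same carbonyl carbon. Among these four compounds, the high numbers stay with those two groups, and the two amides without a ring sit together at the low end, with no compound shown going against this.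

Which part of the (2-hydroxyethyl)(methyl)amino group matters remains open, and a (2-hydroxyethyl)amino group, a plain dimethylamino group or a longer 3-hydroxypropyl chain on the amide nitrogen would separate the hydroxyl, the methyl and the chain length. No available evidence explains why the groups on this carbonyl carbon fall in this order.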